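Piperidin-4-yl to methyl on compound 2

The source may report more compounds than this note shows. Statements on the series, on what has been measured and on what is new or still open speak of the compounds shown alone.

In a functional assay on A549 cells (Homo sapiens) for antiproliferative activity, read by MTT assay, with a stated time of 72 h (a lower number here means a stronger inhibitor, a higher number a weaker inhibitor), compound 1 (`CC(Nc1ncnc2ccc(-c3cnn(C4CCNCC4)c3)cc12)c1c(Cl)ccc(F)c1Cl`) gives 7000 nM and compound 2 (`CC(Nc1nc(N)nc2ccc(-c3cnn(C4CCNCC4)c3)cc12)c1c(Cl)ccc(F)c1Cl`) gives 8800 nM within the scatter of it, while compound 3 (`CC(Nc1ncnc2ncc(-c3cnn(C4CCNCC4)c3)cc12)c1c(Cl)ccc(F)c1Cl`) gives a clearly higher number (29700 nM). Going by the values given here, the one measured step, a 1.3-fold higher number from compound 1 to compound 2 (0.10 log units; within the scatter) for amino in place of hydrogen on an aromatic carbon, stays within the scatter. Compound 4 (`CC(Nc1nc(N)nc2ccc(-c3cnn(C)c3)cc12)c1c(Cl)ccc(F)c1Cl`) keeps the core of compound 2 and takes methyl in place of piperidin-4-yl on an aromatic nitrogen. Among the compounds with values here, every measured compound carries piperidin-4-yl, so no measured step speaks to this change directly. The estimated step in this assay is a 1.6-fold higher number from compound 2 to compound 4 (0.20 log units; within the scatter) as a loose expectation leaning to a higher number. The expected value for compound 4 is 14000 nM within an estimated range of 4500 nM to 40000 nM for now.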

Compound 4, half-maximal inhibitory concentration: > 100000 nM
Compound 4: only a limit was reported; the forecaster's own chance of this, stated with the estimate: 15%; middle value at least 7.1-fold (0.85 log units) from the limit.
By their numbers in this assay, from the lowest: compounds 1 and 2 (each within the scatter of the next); then compound 3. At a limit, above all of these: compound 4.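

The aromatic nitrogen is a sensitive place in this assay: methyl in place of piperidin-4-yl gives an at least 11-fold higher number from compound 2 to compound 4 (1.05 log units; beyond the scatter), whereas the earlier amino change, a 1.3-fold higher number from compound 1 to compound 2 (0.10 log units; within the scatter), stayed within the scatter. Compound 4 is reported only as a limit: the limit of > 100000 nM in this assay, at which 1 of the 4 values shown sits.

The compounds shown leave open whether the ring or the ring nitrogen of piperidin-4-yl carries this difference; cyclohexyl or an open-chain amine such as 2-aminoethyl on this nitrogen would separate the two. Going by these compounds, whether the step holds on the core of compound 1 also remains open.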